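Swapping a Ring on the Chain in a Paw Edema Assay

A few compounds are considered here, and "the series" means these few. Any claim that something is new, unique, unknown or untested is made for them only; others in the source may bear on it.

Four compounds share a core in which an amide-bearing arene carries a carbonyl joined to a double-bonded chain that ends in an aromatic ring. Compound 1 `COc1ccc(/C=C/C(=O)c2ccc(NC(=O)C(C)Br)cc2)cc1` and compound 2 `CC(Br)C(=O)Nc1ccc(C(=O)/C=C/c2ccco2)cc1` differ only in that terminal ring, and so do compound 3 `COc1ccc(/C=C/C(=O)c2ccc(NC(=O)COc3ccc(C(C)=O)cc3)cc2)cc1` and compound 4 `CC(=O)c1ccc(OCC(=O)Nc2ccc(C(=O)/C=C/c3ccco3)cc2)cc1`. How the core of compound 1 differs from the core of compound 3 is not broken down here.

In a functional assay on the whole organism (strain albino) for inhibition, with Rattus norvegicus as the target, read by paw edema, with stated times of 30 min and 3 h, at a dose of 100 mg/kg by the oral route (on this read-out higher numbers stand for more inhibition at the one dose given (going by the name of the read-out) and lower numbers for less inhibition), compound 1 gives 40%. In this assay compound 2 gives 42%. In this assay compound 3 gives 42%, level with compound 2 at the digits shown, and these two are together the highest of the three numbers; the gap to compound 1 lies within the usual scatter, so no order among the three is claimed.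

The change from compound 1 to compound 2 is furan-2-yl in place of 4-methoxyphenyl on a double-bonded chain carbon bound to a double-bonded chain carbon. It made the step of a number 2 percentage points higher from compound 1 to compound 2 (within the scatter). The change from compound 3 to compound 4 is furan-2-yl in place of 4-methoxyphenyl on a double-bonded chain carbon bound to a double-bonded chain carbon, the same change made once more, this time on the core of compound 3; among the compounds shown it occurs twice. Because the earlier step of a number 2 percentage points higher from compound 1 to compound 2 (within the scatter) stayed within the scatter, a step of similar size, a number 2 percentage points higher from compound 3 to compound 4 (within the scatter), is expected here as well. Compound 4 is therefore estimated at 44%, most likely falling between 34% and 54%.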

Compound 4, a percentage reported as inhibition, in the whole organism at one dose (the size of the read-out at that dose, not a potency): 45%
Estimate against measurement, compound 4: 1 percentage points below, and the stated range covers the measured number.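

Putting furan-2-yl in place of 4-methoxyphenyl on a double-bonded chain carbon bound to a double-bonded chain carbon gives a number 3 percentage points higher from compound 3 to compound 4 (within the scatter) in this assay. Set beside the same swap on the core of compound 1, the change reads alike on both cores: the same change on two cores in this assay, a number 2 percentage points higher (within the scatter) from compound 1 to compound 2 and a number 3 percentage points higher (within the scatter) from compound 3 to compound 4, 1 percentage points apart, within the scatter of two such steps. This shows that the five-membered furan-2-yl ring can stand in for the larger 4-methoxyphenyl ring on either core without a readable shift in inhibition, but it does not show that furan-2-yl is the better group, since neither step rises above the scatter, and two cores are too few to promise the same result on a third.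

The compounds shown carry only these two terminal rings, so it remains open whether a ring bearing an amine or a carboxylic acid, or a thiophene-2-yl ring in the same place, would move the read-out clearly beyond the scatter. With only one oral dose shown, it also remains open how inhibition would change at other doses, so these numbers give the size of an effect at that dose and not a potency.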